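From phenyl to 2,3-dimethylphenyl on the shared core

A few compounds are considered here, and "the series" means these few. Any claim that something is new, unique, unknown or untested is made for them only; others in the source may bear on it.

In a functional assay on SGC-7901 cells (Homo sapiens) for antiproliferative activity, read by MTT assay, with a stated time of 72 h (on this read-out higher numbers stand for weaker inhibition and lower numbers for stronger inhibition), compound 3 `COc1cc(-n2cnc3ccc(-c4ccccc4)cc32)cc(OC)c1OC` gives 290 nM, the middle of three measured numbers. Compound 2 `COc1ccc(-c2ccc3ncn(-c4cc(OC)c(OC)c(OC)c4)c3c2)cc1O` gives 44 nM, and compound 1 `COc1cc(-n2cnc3ccc(-c4ccc(C)cc4F)cc32)cc(OC)c1OC` gives 5650 nM. The unmeasured compound 4 `COc1cc(-n2cnc3ccc(-c4cccc(C)c4C)cc32)cc(OC)c1OC` carries 2,3-dimethylphenyl in place of phenyl on an aromatic carbon.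

All three measured compounds differ at this same place, and their steps point in both directions. The phenyl of compound 3 fares much better than the 2-fluoro-4-methylphenyl of compound 1, a large step of a 19-fold lower number from compound 1 to compound 3 (1.29 log units; beyond the scatter). Yet compound 2, with its 3-hydroxy-4-methoxyphenyl, goes against any rule that substituents on this phenyl raise the number, as shown by the modest step of a 6.6-fold higher number from compound 2 to compound 3 (0.82 log units; beyond the scatter). The widest span is a 130-fold lower number from compound 1 to compound 2 (2.11 log units; beyond the scatter), so this place is clearly sensitive to change.

Within the data shown here, compound 1 is the nearer precedent, since its group also carries a methyl, although no measured compound holds two methyl groups. A higher number is therefore expected, by a modest to large step, and probably a smaller one than compound 1 shows. The expected change is a 5.2-fold higher number from compound 3 to compound 4 (0.71 log units; beyond the scatter). Compound 4 is estimated at 1500 nM, within an expected range from 400 nM to 6000 nM.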

Compound 4, half-maximal inhibitory concentration: 3040 nM
For compound 4 the middle estimate is 2.0-fold (0.31 log units) below the measured one, and the stated range covers the measured number.
By their numbers in this assay, from the lowest: compound 2; then compound 3; then compounds 4 and 1 (each within the scatter of the next).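

In this assay, the 2,3-dimethylphenyl group shows that a phenyl carrying only added carbon, with no fluorine, also gives a much higher number than plain phenyl (a 10-fold higher number from compound 3 to compound 4 (1.02 log units; beyond the scatter)). Compound 4 cannot be separated from the compound with the 2-fluoro-4-methylphenyl group (a 1.9-fold lower number from compound 1 to compound 4 (0.27 log units; within the scatter)), yet it stands far from the compound with the 3-hydroxy-4-methoxyphenyl group (a 69-fold higher number from compound 2 to compound 4 (1.84 log units; beyond the scatter)). Among these four compounds, both groups built on a methylphenyl therefore lie on the high side of phenyl, and only compound 2 lies on the low side, though nothing shown here gives a cause for these differences.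

From the compounds shown here alone, it remains open whether a lone hydroxyl or a lone methoxy on this phenyl would reach the low number of compound 2 at 44 nM, or whether the two are needed together. Also open, going by these compounds, is how a single methyl, an amine or a carboxylic acid on this phenyl would fare, and whether the methyl groups raise the number to the same degree at other places on the ring.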